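This account rests on a few compounds, and the source may have more. Where it says the series, first, only, none or still open, it means among the compounds named here.

Compound 3 `COc1cc2ncnc(Nc3ccccn3)c2cc1OC` is one of the weaker entries on the numbers shown. In an assay on MCF7 cells for inhibition of Serine-protein kinase ATM (Homo sapiens), read by immunofluorescence, with a stated time of 1 h (a higher number here means a weaker inhibitor, a lower number a stronger inhibitor), compound 3 gives only a limit of the assay, > 40000 nM. That limit is the limit of > 40000 nM in this assay, at which 2 of the 3 values shown sit. Compound 4 `COc1cc2ncnc(-n3nc(N)nc3N)c2cc1OC` differs from compound 3 in one place: 3,5-diamino-1H-1,2,4-triazol-1-yl in place of (pyridin-2-yl)amino on an aromatic carbon. Within the data shown here, no measured step covers this exchange. Among the measured compounds shown here, the one measured step, an at least 8.0-fold higher number from compound 1 to compound 2 (0.90 log units; beyond the scatter), concerns a different part of the molecule, where compound 1 `COc1cc2ncnc(-n3nc(-c4ccncc4)nc3N)c2cc1OC` carries pyridin-4-yl and gives 5000 nM. Compound 2 `COc1cc2ncnc(-n3nc(C4CCCCC4)nc3N)c2cc1OC` with cyclohexyl reaches only a limit, > 40000 nM. Compound 4 carries neither group, so the step from compound 3 is expected to be small or absent, an at least 1.3-fold lower number from compound 3 to compound 4 (0.12 log units; that floor lies within the scatter). Compound 4 is thus estimated at 30000 nM, within 5000 nM to 80000 nM.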

Compound 4, half-maximal inhibitory concentration: > 40000 nM
Compound 4: a limit, no number; the forecaster's own chance of this, stated with the estimate: 60%; at least 1.3-fold (0.12 log units) between middle value and limit.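

Replacing pyridin-4-yl with amino gives an at least 8.0-fold higher number from compound 1 to compound 4 (0.90 log units; beyond the scatter), so a second group at this place fails to keep the measurable inhibition of compound 1. Compound 4 reaches only a limit in this assay, and that limit is now the commonest result: the limit of > 40000 nM in this assay, at which 3 of the 4 values shown sit. The steps to compound 4 from compound 2 and from compound 3 cannot be read, since both ends of each are limits. From the compounds shown here alone, whether the ring nitrogen of pyridin-4-yl matters stays open. A phenyl group in the same place would test this.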